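Swapping an aryl ester for a fluorophenyl ether

The source may hold more compounds than are shown below. What is called first, only, known or untested is meant among the compounds shown, and "the series" means these compounds.

Compound 1 `CC(C)[C@H](NC(=O)COc1cccc2ccccc12)C(=O)N[C@@H](CC(=O)O)C(=O)COC(=O)c1c(Cl)cccc1Cl` is the anchor of this small set. In a functional assay with Homo sapiens as the target (on this read-out higher numbers stand for weaker inhibition and lower numbers for stronger inhibition), compound 1 gives 11500 nM, the lowest of the three numbers measured, and so the strongest inhibition seen here. Compound 2 `CC(C)[C@H](NC(=O)COc1cccc2ccccc12)C(=O)N[C@@H](CC(=O)O)C(=O)COc1cccc(C(F)(F)F)c1` gives 16600 nM and compound 3 `CC(C)[C@H](NC(=O)COc1cccc2ccccc12)C(=O)N[C@@H](CC(=O)O)C(=O)COc1ccccc1[N+](=O)[O-]` gives 27700 nM. The step of a 1.4-fold higher number from compound 1 to compound 2 (0.16 log units; within the scatter) stays within the scatter, whereas the step of a 2.4-fold higher number from compound 1 to compound 3 (0.38 log units; beyond the scatter) is a modest weakening; the step of a 1.7-fold higher number from compound 2 to compound 3 (0.22 log units; within the scatter) again lies within the scatter.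

Compound 4 `CC(C)[C@H](NC(=O)COc1cccc2ccccc12)C(=O)N[C@@H](CC(=O)O)C(=O)COc1cccc(F)c1` has not yet been measured. Compared with compound 1 the change is 3-fluorophenyl in place of (2,6-dichlorophenyl)carbonyl on an oxygen on a saturated carbon. Like compounds 2 and 3, compound 4 therefore carries an aromatic ring joined directly to the oxygen on the saturated carbon rather than through a carbonyl. The two measured steps of that kind, a 1.4-fold higher number from compound 1 to compound 2 (0.16 log units; within the scatter) and a 2.4-fold higher number from compound 1 to compound 3 (0.38 log units; beyond the scatter), both moved toward weaker inhibition, one within the scatter and one modestly beyond it. For compound 4 a similar, small step toward a higher number is expected, a 1.6-fold higher number from compound 1 to compound 4 (0.19 log units; within the scatter), likely inside or only just outside the scatter. Compound 4 is thus estimated at 18000 nM, with a range from 9000 nM to 36000 nM.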

Compound 4, half-maximal inhibitory concentration: 12000 nM
Compound 4: middle estimate off by 1.5-fold (0.18 log units), on the high side; the measured number falls inside the stated range.
By their numbers in this assay, from the lowest: compounds 1, 4, 2 and 3 (each within the scatter of the next, the first and the last beyond it).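

The ether link at this oxygen carries no visible penalty: in this assay, a 1.0-fold higher number from compound 1 to compound 4 (0.02 log units; within the scatter), so the 3-fluorophenyl group, though it has fewer heavy atoms and no carbonyl, cannot be told apart from the (2,6-dichlorophenyl)carbonyl group it replaces. Compound 4 also shows that the ring on the ether matters, since a 2.3-fold lower number from compound 3 to compound 4 (0.36 log units; beyond the scatter), a modest change, whereas a 1.4-fold lower number from compound 2 to compound 4 (0.14 log units; within the scatter), which leaves fluoro and trifluoromethyl on the aromatic carbon indistinguishable. Nothing available here explains these differences.

The step between compound 3 and compound 4 changes both the group on the ring and its place, so 2-fluorophenyl or 3-nitrophenyl on the same oxygen would be needed to separate those two changes. From the compounds shown here alone, it also remains open how an unsubstituted phenyl, a 3-aminophenyl or a saturated cyclohexyl group on this oxygen would compare with the 3-fluorophenyl of compound 4.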